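A few compounds are considered here, and "the series" means these few. Any claim that something is new, unique, unknown or untested is made for them only; others in the source may bear on it.

Measured so far:
compound 1 `CCCCNc1nc(N)nc2c1CCN(Cc1ccccc1)C2` — 0.4 uM
compound 2 `CCCCNc1nc(N)nc2c1CNCC2` — 7.2 uM

Both compounds were tested in an assay on HEK293 cells for agonist activity at Toll-like receptor 8 (Homo sapiens), read by a luciferase reporter, with a stated time of 6 h; on this read-out lower numbers stand for an effect already at smaller amounts and higher numbers for an effect only at larger amounts of compound. Compound 1 gives 0.4 uM, the lowest of the two numbers. Compound 2 gives 7.2 uM, a higher number, and the gap between them lies beyond the usual scatter. The two compounds differ in more than one place, so this gap alone cannot be tied to a single change.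

Compound 3 `CCCCNc1nc(N)nc2c1CCNC2` has not yet been measured. It is derived from compound 1 by one change: hydrogen in place of benzyl on an amine nitrogen in a ring. For the measured compounds named here, no measured pair shows exactly this change on this core, so the step can only be guessed. Given that compound 2, which also lacks a benzyl group, gives 7.2 uM, the step from compound 1 to compound 3 is expected to go toward higher numbers, beyond the scatter, roughly a 10-fold higher number from compound 1 to compound 3 (1.00 log units; beyond the scatter). Compound 3 is therefore estimated at 4 uM, within a range from 1 uM to 16 uM.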

Compound 3, minimum effective concentration: 0.6 uM
Compound 3: the middle estimate sits 6.7-fold (0.82 log units) above what was measured, outside the stated range (below it).
By their numbers in this assay, from the lowest: compounds 1 and 3 (each within the scatter of the next); then compound 2.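

For the compounds shown here, the swap of benzyl for hydrogen on the amine nitrogen in the ring gives a 1.5-fold higher number from compound 1 to compound 3 (0.18 log units; within the scatter) in this assay and is the first direct reading of this change on the shared core. At this position, then, the benzyl group with its 7 heavy atoms and its six-membered aromatic ring of carbon only can be replaced by a single hydrogen atom with no shift that this read-out can separate from ordinary repeat variation. Going by these compounds alone, the step says nothing about whether the two compounds behave alike in any other test, and it covers only this one pair.

As far as these compounds go, it remains open whether a group of intermediate size on this nitrogen, such as a methyl or a longer chain like butyl, would also leave the number within the scatter, or whether a phenethyl group would shift it. Nothing at hand explains why the benzyl group and hydrogen read alike here.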